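The compounds below may be only part of what the source reports. "The series", "measured", "known", "first", "only" and "open" are said of these compounds alone.

In a functional assay on MCF7 cells (Homo sapiens) for cytotoxicity, read by MTT assay, with a stated time of 72 h (a lower number here means a stronger inhibitor, a higher number a weaker inhibitor), compound 1 (`COC(=O)c1sc2c(C)cccc2c1Nc1cc(OC)c(OC)c(OC)c1`) gives 4550 nM and compound 2 (`COC(=O)c1sc2cc(OC)ccc2c1Nc1cc(OC)c(OC)c(OC)c1`) gives 0.7 nM as the lower of the two numbers, a gap well beyond the scatter. Compound 3 (`COC(=O)c1sc2cc(C)ccc2c1Nc1cc(OC)c(OC)c(OC)c1`) carries methyl in place of methoxy on an aromatic carbon. For the measured compounds named here, no measured pair shows this change on its own, so the size of the step in this assay remains a judgement. The expected direction is toward a weaker inhibitor, with an estimated 11-fold higher number from compound 2 to compound 3 (1.06 log units; beyond the scatter) that lies beyond the scatter. Compound 3 is estimated at 8 nM (range 1 nM to 80 nM).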

Compound 3, half-maximal inhibitory concentration: 1.2 nM
Compound 3: the middle estimate sits 6.7-fold (0.82 log units) above what was measured; the range from low to high includes it.
By their numbers in this assay, from the lowest: compounds 2 and 3 (each within the scatter of the next); then compound 1.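

In this assay the first direct test of this change gives a 1.7-fold higher number from compound 2 to compound 3 (0.23 log units; within the scatter), so methoxy and methyl at this aromatic carbon cannot be told apart. The methoxy oxygen and its hydrogen-bond acceptor leave in this change, yet the value stays in the same low range, so this pair does not depend on that acceptor. Nothing available explains this match.

Still open, from the compounds shown here alone, is how far this tolerance extends. An amine, a carboxylic acid or a longer chain at this carbon could give a very different number.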